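A few compounds are considered here, and "the series" means these few. Any claim that something is new, unique, unknown or untested is made for them only; others in the source may bear on it.

Measured so far:
- compound 1, `O=S(=O)(Nc1cccc2c1CCCC2c1c[nH]cn1)C1CC1`: 537 nM
- compound 2, `CCS(=O)(=O)Nc1cccc(NC2=NCCN2)c1`: 2950 nM
- compound 3, `CS(=O)(=O)Nc1ccc(O)c2c1CCCC2c1c[nH]cn1`: 708 nM

All three were run in an assay on isolated protein for binding affinity to Alpha-1A adrenergic receptor (Rattus norvegicus), read by radioligand binding; a higher number here means a weaker inhibitor, a lower number a stronger inhibitor. Compound 1 stands at the low end of the three numbers; compound 3 is within the usual scatter of it, so no order between them can be claimed, while compound 2 alone stands beyond the scatter at the high end. For the measured compounds named here, no pair among the measured compounds differs in a single place, so nothing is known of how any one change moves the number.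

Compound 4, `CC(C)S(=O)(=O)Nc1cccc2c1CCCC2c1c[nH]cn1`, is not yet measured in this assay. It differs from compound 1 in one place: isopropyl in place of cyclopropyl on a sulfonyl sulfur. The group that leaves and the group that enters carry the same count of heavy atoms, no donors and no acceptors; only the three-membered ring is lost. The step from compound 1 to compound 4 is expected to stay within the scatter, with no clear direction, as a 1.1-fold higher number from compound 1 to compound 4 (0.05 log units; within the scatter). Compound 4 is therefore estimated at 600 nM, within 250 nM to 1500 nM.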

Compound 4, inhibition constant: 1150 nM
Estimate against measurement, compound 4: 1.9-fold (0.28 log units) below, and the stated range covers the measured number.
By their numbers in this assay, from the lowest: compounds 1, 3 and 4 (each within the scatter of the next, the first and the last beyond it); then compound 2.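

In this assay, for the compounds shown here, the sulfonyl sulfur gives the only single-place comparison: isopropyl in place of cyclopropyl gives a 2.1-fold higher number from compound 1 to compound 4 (0.33 log units; beyond the scatter) and this modest step lies beyond the scatter. This position therefore responds to the change, even though the group that leaves and the group that enters carry the same count of heavy atoms and the three-membered ring is the only listed difference between them. No measurement shown here bears on the origin of the step, so the loss of the ring describes the change and does not explain it.

Going by these compounds, how a longer chain such as butyl, or an amine, would read on the sulfonyl sulfur remains open. On these data alone, whether the same swap gives a similar step with a hydroxyl group on the core, as in compound 3, also remains open.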